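A few compounds are considered here, and "the series" means these few. Any claim that something is new, unique, unknown or untested is made for them only; others in the source may bear on it.

Among the compounds with values here, in an ADME assay on microsomes from liver (Homo sapiens) for pharmacokinetics, read by LC-MS, using NADPH, with a stated time of 30 min, tested at 1 uM (a lower number here means slower removal, a higher number faster removal of the compound), three compounds have numbers so far. Compound 1 `CC[C@H]1CC[C@H](C2=NC3(CCN(S(=O)(=O)CCc4c(C)cc(N(C)C(N)=O)cc4C)CC3)C(=O)N2)CC1` gives 170 mL.min-1.g-1, compound 2 `Cc1cc(N2C(=O)CNC2=O)cc(C)c1CCS(=O)(=O)N1CCC2(CC1)N=C([C@H]1CC[C@H](C)CC1)NC2=O` gives 53 mL.min-1.g-1, and compound 3 `Cc1cc(N2C(=O)NC(=O)C2C)cc(C)c1CCS(=O)(=O)N1CCC2(CC1)N=C(c1ccc(OC(F)(F)F)cc1)NC2=O` gives 71 mL.min-1.g-1. Compound 3 therefore lies within the scatter of compound 2, while compound 1 has the highest number, beyond the scatter of both. Compound 4 `CCC1(CC)C(=O)NC(=O)N1c1cc(C)c(CCS(=O)(=O)N2CCC3(CC2)N=C(c2ccc(OC(F)(F)F)cc2)NC3=O)c(C)c1` has 5,5-diethyl-2,4-dioxoimidazolidin-1-yl in place of the 5-methyl-2,4-dioxoimidazolidin-1-yl of compound 3 on an aromatic carbon: 5,5-diethyl-2,4-dioxoimidazolidin-1-yl in place of 5-methyl-2,4-dioxoimidazolidin-1-yl on an aromatic carbon. Within the data shown here, no measured pair differs in one place only, so this forecast is loose. A modest rise that may stay within the scatter is expected, with an estimated 1.5-fold higher number from compound 3 to compound 4 (0.19 log units; within the scatter). For compound 4 the estimated value is 110 mL.min-1.g-1, with an expected range from 55 mL.min-1.g-1 to 220 mL.min-1.g-1.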

Compound 4, intrinsic clearance in microsomes: 29 mL.min-1.g-1
The estimate for compound 4 lay 3.8-fold (0.58 log units) above the measured number, and the stated range ends above it.
By their numbers in this assay, from the lowest: compounds 4, 2 and 3 (each within the scatter of the next, the first and the last beyond it); then compound 1.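

In this assay, within the data shown here, 5,5-diethyl-2,4-dioxoimidazolidin-1-yl in place of 5-methyl-2,4-dioxoimidazolidin-1-yl gives a 2.4-fold lower number from compound 3 to compound 4 (0.39 log units; beyond the scatter) and is the first single-place step here. It shows that this position on the aromatic ring can change the read-out, and that a group with more carbon atoms here can go with slower removal, not faster. No measurement available explains this drop.

From the compounds shown here alone, it remains open whether a longer chain than ethyl, or an amine or carboxylic acid on this ring, would give a similar number. Going by these compounds, whether the same change works alongside the other groups on the shared core is also open.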